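Nitro to acetoxy on the aryl ring

The source may hold more compounds than are shown below. What is called first, only, known or untested is meant among the compounds shown, and "the series" means these compounds.

In a functional assay on Bel7402/5-FU cells (Homo sapiens) for cytotoxicity, read by MTT assay, with a stated time of 72 h (on this read-out higher numbers stand for weaker inhibition and lower numbers for stronger inhibition), compound 1 `O=C1C=CCC/C1=C\C=C\c1ccc(Br)cc1` gives 4300 nM, and compound 2 `O=C1C=CCC/C1=C\C=C\c1ccc([N+](=O)[O-])cc1` gives 4500 nM. Within the data shown here, the only measured step, a 1.0-fold higher number from compound 1 to compound 2 (0.02 log units; within the scatter), lies within the scatter. Compound 2 therefore stands level with compound 1, and the pair cannot be ranked.

The next compound is compound 3 `CC(=O)Oc1ccc(/C=C/C=C2\CCC=CC2=O)cc1`, which keeps the shared core and carries acetoxy in place of nitro on an aromatic carbon. In words, this is acetoxy in place of nitro on an aromatic carbon, para to a large group.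

Among the measured compounds shown here, one measured step bears on this change: the exchange of nitro for bromo on the same aromatic carbon, a 1.0-fold higher number from compound 1 to compound 2 (0.02 log units; within the scatter). That exchange did not move the number beyond the scatter, so no clear shift is expected in this assay for the new exchange. For the measured compounds named here, this is thin evidence, since it rests on a single step and no compound with an acetoxy group has been measured. The range is kept wide for that reason.

The expected step is a 1.1-fold higher number from compound 2 to compound 3 (0.05 log units; within the scatter), which is no change beyond the scatter. For compound 3 the estimate is 5000 nM, with an expected range of 2000 nM to 12000 nM.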

Compound 3, half-maximal inhibitory concentration: 4100 nM
Estimate against measurement, compound 3: 1.2-fold (0.09 log units) above, within the range that was stated.
By their numbers in this assay, from the lowest: compounds 3, 1 and 2 (each within the scatter of the next).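

In this assay the exchange of nitro for acetoxy on this aromatic carbon, para to a large group, gives a 1.1-fold lower number from compound 2 to compound 3 (0.04 log units; within the scatter) and stays within the scatter. The exchange of bromo for acetoxy at the same place gives a 1.0-fold lower number from compound 1 to compound 3 (0.02 log units; within the scatter) and also stays within the scatter. Where the earlier pair offered a single exchange, this position has now carried bromo, nitro and acetoxy, and compound 1, compound 2 and compound 3 remain level and cannot be ranked, so none of the three exchanges shown separates them on this read-out. Nothing available explains why these three groups give values within the scatter of one another.

On these data alone, whether this level holds for other kinds of group on the same aromatic carbon stays open, for example an amine, a carboxylic acid or a longer chain such as butoxy. All the compounds shown share the same core and differ at this one place, so how changes elsewhere, for instance on the carbonyl-bearing ring or in the linking chain, would affect the number also stays open.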